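Series notes: fluoro in place of amino, antiproliferative read-out

The source may hold more compounds than are shown below. What is called first, only, known or untested is meant among the compounds shown, and "the series" means these compounds.

Measured so far:
Compound 1 `Nc1ccc2c(c1)OCCCN2S(=O)(=O)c1ccc(-c2cnc(C3CC3)o2)cc1`: 33 nM
Compound 2 `COc1ccc2c(c1)N(S(=O)(=O)c1ccc(-c3cnc(C4CC4)o3)cc1)CCCO2`: 14 nM
Compound 3 `O=S(=O)(c1ccc(-c2cnc(C3CC3)o2)cc1)N1CCCc2ccccc21`: 38 nM

All values come from a functional assay on PC-3 cells (Homo sapiens) for antiproliferative activity, read by MTT assay, with a stated time of 72 h; on this read-out lower numbers stand for stronger inhibition and higher numbers for weaker inhibition. Compound 1 gives the second highest number of the three; its gap to compound 3 lies within the scatter, while compound 2 sits beyond the scatter with the lower number. Compound 4 `O=S(=O)(c1ccc(-c2cnc(C3CC3)o2)cc1)N1CCCOc2cc(F)ccc21` is not yet measured in this assay. It differs from compound 1 in one place: fluoro in place of amino on an aromatic carbon. Among the measured compounds shown here, no pair of measured compounds shows a step of this kind, so nothing here bears directly on the change. The expectation in this assay is a small step, not beyond the scatter, with no clear direction. Compound 4 is therefore estimated at 30 nM, with a range of 12 nM to 75 nM, meaning an expected step of a 1.1-fold lower number from compound 1 to compound 4 (0.04 log units; within the scatter).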

Compound 4, half-maximal inhibitory concentration: 42 nM
The estimate for compound 4 lay 1.4-fold (0.15 log units) below the measured number; measured number inside the range.
By their numbers in this assay, from the lowest: compound 2; then compounds 1, 3 and 4 (each within the scatter of the next).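

In this assay the exchange at this aromatic carbon gives a 1.3-fold higher number from compound 1 to compound 4 (0.10 log units; within the scatter) and so shows no step beyond the scatter. At this position, then, the loss of the amino group's hydrogen-bond donor and acceptor comes with no separable difference in the antiproliferative read-out. No measurement on hand accounts for this result. The compounds shown leave open whether any group at this carbon matters, since neither hydrogen nor chloro is available on the same core. A hydroxyl or acetamido group there would test whether larger or different substituents are equally accommodated.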